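The source may report more compounds than this note shows. Statements on the series, on what has been measured and on what is new or still open speak of the compounds shown alone.

Compound 3 `COc1cc(C(c2ccc(O)c(OC)c2)[C@H](C)[C@@H](C)CO)ccc1O` sits at the edge of what the numbers show: in a functional assay on HeLa cells (Homo sapiens) for cytotoxicity, read by WST assay, with a stated time of 48 h (on this read-out higher numbers stand for weaker inhibition and lower numbers for stronger inhibition), compound 3 gives > 100000 nM, which is a limit of the assay rather than a measured number. Its close relatives were measured. Compound 1 `COc1cc(C(c2ccc(O)c(OC)c2)[C@H](C)[C@@H](C)CF)ccc1O` gives 34000 nM in this assay, and compound 2 `COC[C@H](C)[C@@H](C)C(c1ccc(O)c(OC)c1)c1ccc(O)c(OC)c1` gives 77000 nM. Two steps lead away from compound 1: a 2.3-fold higher number from compound 1 to compound 2 (0.36 log units; beyond the scatter) and an at least 2.9-fold higher number from compound 1 to compound 3 (0.46 log units; beyond the scatter). The step that bears directly on the change at hand is an at least 1.2-fold higher number from compound 2 to compound 3 (0.11 log units; that floor lies within the scatter), whose size is known only as a floor because of the limit of > 100000 nM in this assay, at which 1 of the 3 values shown sits.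

Compound 4 `COC[C@@H](C)[C@@H](C)C(c1ccc(O)c(OC)c1)c1ccc(O)c(OC)c1` carries the change (1-(methoxymethyl)ethyl in place of 1-(hydroxymethyl)ethyl on a saturated chain carbon bound to two saturated chain carbons). This runs the step from compound 2 to compound 3 in reverse, so the number is expected to fall, by an amount that can only be guessed from a floor. Compound 4 is estimated at 80000 nM, within 30000 nM to 200000 nM, corresponding to an expected at least 1.2-fold lower number from compound 3 to compound 4 (0.09 log units; that floor lies within the scatter) in this assay.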

Compound 4, half-maximal inhibitory concentration: > 100000 nM
Compound 4: no number, only a limit; the forecaster's own chance of this, stated with the estimate: 35%; middle value at least 1.2-fold (0.09 log units) from the limit.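

In this assay the step from compound 3 to compound 4 cannot be read, because both values are limits of the assay: the limit of > 100000 nM in this assay, at which 2 of the 4 values shown sit. The new pair that differs only in drawn configuration gives an at least 1.2-fold higher number from compound 2 to compound 4 (0.11 log units; that floor lies within the scatter), and this floor shows no clear effect of that stereocentre: the fact that compounds 2 and 4 differ only in the configuration as drawn. Compound 4 also lies on the weaker side of compound 1, with an at least 2.9-fold higher number from compound 1 to compound 4 (0.46 log units; beyond the scatter), so the 1-(fluoromethyl)ethyl compound keeps the lowest number among these four.

As far as these compounds go, how far compound 3 and compound 4 lie past the limit stays unknown, and so does whether the methyl on that oxygen changes anything. From the compounds shown here alone, it is also open whether a group carrying an amine or a carboxylic acid, in place of 1-(fluoromethyl)ethyl, would give a lower number than compound 1.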